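This account rests on a few compounds, and the source may have more. Where it says the series, first, only, none or still open, it means among the compounds named here.

In an ADME assay on KB cells (Homo sapiens) for cytotoxicity (on this read-out lower numbers stand for an effect already at smaller amounts and higher numbers for an effect only at larger amounts of compound), compound 1 `COC(=O)N1[C@@H]2C=C[C@@](OC)(C(=O)c3c2cc(OC)c(OC)c3OCc2ccccc2)N1C(=O)OC` reads > 300 ug/mL, and this value is a limit of the assay. Within the data shown here, compound 2 `COC(=O)N1[C@@H]2C=C[C@@](OC)(C(=O)c3c2cc(OC)c(OC)c3OCc2ccc(Cl)cc2)N1C(=O)OC` gives 55.9 ug/mL, the only actual number so far. Compound 3 `CCCCOc1c(OC)c(OC)cc2c1C(=O)[C@]1(OC)C=C[C@H]2N(C(=O)OC)N1C(=O)OC` keeps the shared core but carries propyl in place of 4-chlorophenyl on a saturated chain carbon bound to an oxygen on an aromatic ring. Among the measured compounds shown here, only one measured step bears on this change: chloro in place of hydrogen on an aromatic carbon, an at least 5.3-fold lower number from compound 1 to compound 2 (0.72 log units; beyond the scatter). For the measured compounds named here, compound 3 loses that chloro along with the aromatic ring, so a move back toward higher numbers seems likely, though no measured step shows the effect of a propyl group. The expected step, moderate in size and toward a higher number, is a 2.1-fold higher number from compound 2 to compound 3 (0.33 log units; beyond the scatter). For compound 3, the estimated value is 120 ug/mL, with an expected range from 35 ug/mL to 400 ug/mL.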

Compound 3, concentration for half-maximal effect: > 300 ug/mL
Compound 3 ended at the assay's limit; the forecaster's own chance of this, stated with the estimate: 25%; at least 2.5-fold (0.39 log units) between middle value and limit.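

In this assay, propyl in place of 4-chlorophenyl on a saturated chain carbon bound to an oxygen on an aromatic ring gives an at least 5.3-fold higher number from compound 2 to compound 3 (0.72 log units; beyond the scatter), so the lower number of compound 2 does not carry over to this smaller group. Of the three compounds, only compound 2, with its chloro-bearing ring, gives a number that is not a limit, while the phenyl of compound 1 and the propyl of compound 3 both end at a limit. The step from compound 1 to compound 3 cannot be read: the limit of > 300 ug/mL in this assay, at which 2 of the 3 values shown sit.

As far as these compounds go, it remains open whether the chloro needs the aromatic ring to lower the number, or whether a chloro at the end of a butyl chain would do the same. From the compounds shown here alone, it is equally open how a bromo or a methoxy on the phenyl ring, or an amine on a longer chain, would read.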